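The source may hold more compounds than are shown below. What is called first, only, known or untested is meant among the compounds shown, and "the series" means these compounds.

The compounds here share one core that carries two aryl groups on double-bonded chain carbons, and they are tested in a functional assay on K562 cells (Homo sapiens) for cytotoxicity, read by CCK-8 assay, with a stated time of 72 h; on this read-out higher numbers stand for weaker inhibition and lower numbers for stronger inhibition. Compound 1 `COc1ccccc1/C=c1/[nH]c(=O)/c(=C\c2cccc(Cl)c2Cl)[nH]c1=O` is reported in this assay as "not active" (no number reported), so it contributes no number. Compound 2 `C=CCn1c(=O)/c(=C\c2cc(Br)ccc2F)[nH]c(=O)/c1=C\c1ccccc1OC` gives in this assay 5100 nM. Among the compounds with values here, that makes compound 2 the only compound with a numeric result; compound 1 stands beside it without one, so no measured step between two compounds is available. Compound 3 `C=CCn1c(=O)/c(=C\c2ccc(C)cc2)[nH]c(=O)/c1=C\c1ccccc1OC` has not yet been tested in this assay. It differs from compound 2 in one place: 4-methylphenyl in place of 5-bromo-2-fluorophenyl on a double-bonded chain carbon bound to an aromatic carbon. Within the data shown here, with no measured step to draw on, nothing in the data says which way this exchange should move the read-out, and the expected step of a 1.6-fold higher number from compound 2 to compound 3 (0.20 log units; within the scatter) is set as a modest weakening that need not go beyond the usual scatter. Compound 3 is therefore expected to give 8000 nM in this assay, within a range from 2500 nM to 25000 nM, with a real chance that only a limit and no number is reported.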

Compound 3, half-maximal inhibitory concentration: "not active" (no number reported)
Compound 3: no number reported, and the estimate cannot be compared.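

Compound 3 is reported as "not active" (no number reported) and so offers no number to set against compound 2, which means no new step can be read. The compounds shown leave open how much the exchange of 5-bromo-2-fluorophenyl for 4-methylphenyl shifts the read-out. No further evidence bears on this result.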